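The compounds below may be only part of what the source reports. "The series", "measured", "known", "first", "only" and "open" are said of these compounds alone.

Working notes on the shared core, all compounds read in a functional assay on PC-3 cells (Homo sapiens) for antiproliferative activity, read by MTT assay, with a stated time of 48 h; on this read-out lower numbers stand for stronger inhibition and higher numbers for weaker inhibition.

Compound 1 `CS(=O)(=O)c1ccc(Nc2nccc(Nc3nc4ccc(F)cc4s3)n2)cc1` gives 1940 nM. Compound 3 `COc1ccc2nc(Nc3nc(Nc4ccc(S(C)(=O)=O)cc4)ncc3F)sc2c1` gives 1270 nM. Compound 2 `CS(=O)(=O)c1ccc(Nc2ncc(F)c(Nc3nc4ccc(Cl)cc4s3)n2)cc1` returns only a limit of the assay, > 50000 nM, so no number is known for it. Among the three values shown, compound 2 therefore stands apart at the weak end, at the limit described by the limit of > 50000 nM in this assay, at which 1 of the 3 values shown sits. Among the measured compounds shown here, the single measured step that starts from compound 2, an at least 39-fold lower number from compound 2 to compound 3 (1.59 log units; beyond the scatter), changes a group at another site of the core and says only that one change at that site carries compound 2 well clear of the limit.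

Compound 4 `CS(=O)(=O)c1ccc(Nc2nccc(Nc3nc4ccc(Cl)cc4s3)n2)cc1` differs from compound 2 by hydrogen in place of fluoro on an aromatic carbon. For the measured compounds named here, no measured step addresses this position, so the size of the step is not fixed by the data. Going by the values given here, compound 1 likewise carries hydrogen at this position, with fluoro rather than chloro at the other site, and sits at a measurable value; the pair compound 1 and compound 4 has no measured step. The expectation for compound 4 is a number rather than a limit, with the step of an at least 12-fold lower number from compound 2 to compound 4 (1.09 log units; beyond the scatter) estimated as a move toward stronger inhibition. Compound 4 is estimated at 4000 nM, in the range 800 nM to 30000 nM.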

Compound 4, half-maximal inhibitory concentration: > 50000 nM
Compound 4 was reported as a limit; the forecaster's own chance of this, stated with the estimate: 25%; middle value at least 12-fold (1.09 log units) from the limit.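

In this assay compound 4 returns only a limit of the assay, > 50000 nM, so hydrogen in place of fluoro on this aromatic carbon does not bring the chloro compound to a measurable value, and the step between the two limits cannot be read. With hydrogen at this position, the change at the other site now has a readable size, an at least 25-fold higher number from compound 1 to compound 4 (1.41 log units; beyond the scatter), for chloro in place of fluoro on an aromatic carbon. Chloro at that other site therefore goes with the limit whether this position carries fluoro or hydrogen, a pattern that rests on compound 2 and compound 4 alone: the limit of > 50000 nM in this assay, at which 2 of the 4 values shown sit.

What fluoro contributes at this position remains unknown, as the compounds shown include no pair differing only in hydrogen and fluoro here with both values measurable. Also open, on these data alone, is how an amine or a methoxy group at this position would read, and whether either would bring a chloro compound to a measurable value.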